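Hydroxy to methoxy on compound 1: cytotoxicity outlook

The source may hold more compounds than are shown below. What is called first, only, known or untested is meant among the compounds shown, and "the series" means these compounds.

Measured so far:
compound 1, `O=C(Nc1ccc(Sc2nc3ccccc3s2)c(Cl)c1)c1ccccc1O`, gives 64000 nM in an ADME assay on HEK293 cells (Homo sapiens) for cytotoxicity, read by reporter gene assay and resazurin assay, with a stated time of 48 h; on this read-out higher numbers stand for lower toxicity in this test and lower numbers for higher toxicity in this test.
compound 2, `O=C(Nc1ccc(Sc2nc3ccccc3s2)cc1)c1ccccc1O`, gives 74000 nM in this assay.

Among the measured compounds shown here, compound 1 holds the lowest of the two numbers; its only neighbour is compound 2, reached by hydrogen in place of chloro on an aromatic carbon, with a 1.2-fold higher number from compound 1 to compound 2 (0.06 log units; within the scatter), a step that stays within the scatter. Both measured compounds therefore sit at essentially the same level of this read-out.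

Compound 3, `COc1ccccc1C(=O)Nc1ccc(Sc2nc3ccccc3s2)c(Cl)c1`, has not been measured. It differs from compound 1 by methyl in place of hydrogen on an oxygen on an aromatic ring, that is hydroxy to methoxy, 2-hydroxyphenyl to 2-methoxyphenyl. For the measured compounds named here, none of the measured steps touches this oxygen; the single step from compound 1 to compound 2 sits on another part of the shared core and was itself within the scatter. There is thus no measured ground for a movement in this assay beyond the scatter in either direction, and the outlook rests on the level of compound 1 alone.

Compound 3 is expected near 64000 nM, with a range from 25000 nM to 160000 nM. The step this estimate implies, no change at the digits printed from compound 1 to compound 3 (within the scatter), is expected to lie within the scatter.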

Compound 3, half-maximal cytotoxic concentration: > 100000 nM
Compound 3: a limit, no number; the forecaster's own chance of this, stated with the estimate: 25%; at least 1.5-fold (0.19 log units) between middle value and limit.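

In this assay compound 3 gives > 100000 nM, a limit of the assay and not a number. Among the compounds shown here, this is the first reading at the oxygen on the aromatic ring: methyl in place of hydrogen there gives an at least 1.5-fold higher number from compound 1 to compound 3 (0.19 log units; that floor lies within the scatter), so this change shows no move towards a lower number, that is, towards higher toxicity in this test, whereas the earlier step from chloro to hydrogen concerned another place on the shared core and stayed within the scatter. Among the compounds shown, the reading at this limit belongs to the methoxy compound alone, and the data show that the free hydroxy hydrogen is not required for a reading this high, though they give no cause for it: the limit of > 100000 nM in this assay, at which 1 of the 3 values shown sits.

On these data alone, whether the true step from hydroxy to methoxy lies beyond the scatter stays open, since only its floor can be read and that floor lies within the scatter. Also open, as far as these compounds go, is how this assay responds to a longer chain such as ethoxy or to an amine at this place, and whether methoxy gives the same reading on the core of compound 2, which carries hydrogen in place of chloro.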